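The source may report more compounds than this note shows. Statements on the series, on what has been measured and on what is new or still open speak of the compounds shown alone.

Working notes on a small series of pyrazolyl enones tested in a functional assay on SW-620 cells (Homo sapiens) for cytotoxicity, read by sulforhodamine B assay, with a stated time of 48 h, tested at 1 uM; on this read-out higher numbers stand for a weaker effect at the one concentration tested and lower numbers for a stronger effect.

Compound 3 `COc1ccc(-c2cc(/C=C/C(=O)c3ccc(N)cc3)[nH]n2)cc1OC` gives 95% in this assay. Compound 1 `COc1cc(-c2cc(/C=C/C(=O)c3ccc(N)cc3)[nH]n2)cc(OC)c1OC` carries one more methoxy group on the aryl ring attached to the pyrazole; the change is methoxy in place of hydrogen on an aromatic carbon, and in this assay compound 1 gives 82%, so that a number 13 percentage points lower from compound 3 to compound 1 (beyond the scatter). Compound 2 `COc1ccc(C(=O)/C=C/c2cc(-c3cc(OC)c(OC)c(OC)c3)n[nH]2)cc1OC` keeps the trimethoxyphenyl on the pyrazole and exchanges the ketone aryl group, giving 70% in this assay; here a number 12 percentage points lower from compound 1 to compound 2 (beyond the scatter). Compound 2 thus has the lowest number of the three measured compounds, with compound 1 nearest and compound 3 furthest.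

Compound 4 `COc1cc(C(=O)/C=C/c2cc(-c3cc(OC)c(OC)c(OC)c3)n[nH]2)cc(OC)c1OC` is the next member and is not yet measured. Relative to compound 2 the change is methoxy in place of hydrogen on an aromatic carbon. The surroundings of the entering group read the same as for the change from compound 3 to compound 1, so this is the same change, made here on the ketone side rather than on the pyrazole side; the difference between the two cores, compound 2 against compound 3, is not broken down here.

For compound 4 in this assay a step of a number 10 percentage points lower from compound 2 to compound 4 (within the scatter) is expected, resting on the same change having given a number 13 percentage points lower from compound 3 to compound 1 (beyond the scatter), with some uncertainty because the ring that receives the group is not the one that received it before. The estimate for compound 4 is 60%, with a likely range from 45% to 78%.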

Compound 4, a percentage reported as activity, at one concentration (the size of the read-out at that concentration, not a potency): 85%
Beside the measured number, compound 4's estimate is 25 percentage points below it, and the stated range ends below it.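

In this assay, methoxy in place of hydrogen on an aromatic carbon gives a number 15 percentage points higher from compound 2 to compound 4 (beyond the scatter), so the change does not carry its direction from one core to the other: the same change on two cores in this assay, a number 13 percentage points lower (beyond the scatter) from compound 3 to compound 1 and a number 15 percentage points higher (beyond the scatter) from compound 2 to compound 4, 28 percentage points apart, beyond the scatter of two such steps

For this series, then, the step seen on the core of compound 3 cannot simply be transferred to the core of compound 2, and the entry of a methoxy group has no single sign across the listed pairs. For the compounds shown here, this does not show what sets the difference: the two steps come from only one pair on each core, the receiving ring differs as well as the core, and the read-out reports the size of the effect at one concentration rather than a potency.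

From the compounds shown here alone, whether the opposite signs belong to methoxy itself or would also appear with a hydroxy group, an ethoxy group or a fluorine atom on the same aromatic carbon remains open. Also open, going by these compounds, is whether a further pair on either core, carrying a longer alkoxy chain or a chlorine atom, would follow the step of its own core or the step of the other.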